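The compounds below may be only part of what the source reports. "The series", "measured", "known", "first", "only" and "open" are said of these compounds alone.

Among the measured compounds shown here, in an ADME assay on a cell-free system (plasma, Mus musculus) for metabolic stability, read by LC-MS, tested at 2 uM (a lower number here means that the compound disappears faster, a higher number that the compound lasts longer), only two compounds have been measured so far. Compound 1 `CC(C)CNC(=O)n1cc(-c2ccccc2)oc1=O` gives > 2 h, which is a limit of the assay and not a number. Compound 2 `COc1cccc(-c2cn(C(=O)NCCCCc3ccccc3)c(=O)o2)c1` gives > 2 h, which is also a limit and not a number. Together they show (the limit of > 2 h in this assay, at which 2 of the 2 values shown sit), so compound 2 has no exact figure to start from. Compound 3 `O=C(NCCCCc1ccccc1)n1cc(-c2ccncc2)oc1=O` carries pyridin-4-yl in place of 3-methoxyphenyl on an aromatic carbon, next to the ring oxygen: pyridin-4-yl in place of 3-methoxyphenyl on an aromatic carbon. For the measured compounds named here, no measured pair differs in one place only, so the data give no size for a change of this kind. No shift beyond the usual scatter is expected in this assay, and the estimated change is a step that the limit leaves unreadable from compound 2 to compound 3. For compound 3 the expected half-life is 2.5 h, with an estimated range of 1 h to 5 h.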

Compound 3, half-life: 0.5 h
Estimate against measurement, compound 3: 5.0-fold (0.70 log units) above, outside the stated range (below it).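

In this assay, putting pyridin-4-yl in place of 3-methoxyphenyl on this aromatic carbon, next to the ring oxygen, gives an at least 4.0-fold lower number from compound 2 to compound 3 (0.60 log units; beyond the scatter). Among the compounds shown here, the earlier compounds could not show that the half-life responds to a change at this position, and compound 3 is the first with an exact figure. The step can be given only as a minimum size, because its starting point is a limit and not a number: the limit of > 2 h in this assay, at which 2 of the 3 values shown sit.

This single exchange does not separate the arrival of the ring nitrogen from the loss of the methoxy group. Going by these compounds, whether pyridin-3-yl at this position, with the rest of compound 3 kept, would also give a shorter half-life remains open.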